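Moving a chlorine: what to expect of compound 3

A few compounds are considered here, and "the series" means these few. Any claim that something is new, unique, unknown or untested is made for them only; others in the source may bear on it.

Compound 1 `CC1=CC[C@@H]([C@@](C)(O)CCCC(C)(C)NC(=S)N/N=C\c2ccc(O)cc2)CC1`: 8390 nM
Compound 2 `CC1=CC[C@@H]([C@@](C)(O)CCCC(C)(C)NC(=S)N/N=C\c2ccccc2Cl)CC1`: > 100000 nM (a limit)

Both compounds were tested in a functional assay on NCI/ADR cells (Homo sapiens) for cytotoxicity, read by sulforhodamine B assay; on this read-out lower numbers stand for stronger inhibition of growth and higher numbers for weaker inhibition of growth. Compound 2 gives > 100000 nM, which is a limit of the assay and not a number.

Compound 3 `CC1=CC[C@@H]([C@@](C)(O)CCCC(C)(C)NC(=S)N/N=C\c2cccc(Cl)c2)CC1` differs from compound 2 in one place: 3-chlorophenyl in place of 2-chlorophenyl on a carbon with a double bond to nitrogen. Going by the values given here, the group changes on a carbon with a double bond to nitrogen, and only one measured step touches that place. It is large: an at least 11-fold higher number from compound 1 to compound 2 (1.07 log units; beyond the scatter). This shows that the group there can matter greatly in this assay. However, that step exchanged 4-hydroxyphenyl for 2-chlorophenyl, whereas the new change keeps the same atoms and only joins them differently. Among the compounds with values here, no measured pair shows what such a shift does.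

Within the data shown here, the only exact number in this small set is from compound 1, at 8390 nM. A moderate step towards a lower number is therefore expected, although another result at the limit remains quite possible. The estimated step is an at least 2.5-fold lower number from compound 2 to compound 3 (0.39 log units; beyond the scatter). For compound 3 the expected value is 40000 nM, with an estimated range from 10000 nM to 100000 nM.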

Compound 3, concentration for 50% growth inhibition: 7350 nM
The estimate for compound 3 lay 5.4-fold (0.74 log units) above the measured number, outside the stated range (below it).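

In this assay, the swap of 2-chlorophenyl for 3-chlorophenyl gives an at least 13-fold lower number from compound 2 to compound 3 (1.13 log units; beyond the scatter), so the same atoms, joined differently, can separate a compound with a measured effect from one at the limit, something the earlier step could not show, as it exchanged one whole group for a different one. As far as these compounds go, the value of compound 2, > 100000 nM, is a limit and not a number, so the true size of this step stays unknown: the limit of > 100000 nM in this assay, at which 1 of the 3 values shown sits. The exchange of 4-hydroxyphenyl for 3-chlorophenyl gives a 1.1-fold lower number from compound 1 to compound 3 (0.06 log units; within the scatter), so a chlorophenyl group at this place is not in itself a loss, and among these three compounds only the 2-chlorophenyl group of compound 2 stands apart.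

From the compounds shown here alone, whether 4-chlorophenyl would behave like 3-chlorophenyl or like 2-chlorophenyl remains open, as does what a phenyl ring carrying a methoxy group or an amine would give at this place. The three values also give no explanation of why 2-chlorophenyl and 3-chlorophenyl differ so strongly.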